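The source may report more compounds than this note shows. Statements on the series, on what has been measured and on what is new or still open speak of the compounds shown alone.

Working notes on the aryl ether series. Three analogues on the shared core have been run in a functional assay on cells for inhibition, with Murine T-cell line (Mus musculus) as the target; on this read-out higher numbers stand for weaker inhibition and lower numbers for stronger inhibition. Compound 1 `CC[C@@H]1/C=C(\C)C[C@H](C)C[C@H](OC)[C@H]2O[C@@](O)(C(=O)C(=O)N3CCCC[C@H]3C(=O)O[C@H](/C(C)=C/[C@@H]3CC[C@@H](Oc4cccc(C)c4)[C@H](OC)C3)[C@H](C)[C@@H](O)CC1=O)[C@H](C)C[C@@H]2OC` carries 3-methylphenyl and in this assay compound 1 gives 5.4 nM. Compound 2 `CC[C@@H]1/C=C(\C)C[C@H](C)C[C@H](OC)[C@H]2O[C@@](O)(C(=O)C(=O)N3CCCC[C@H]3C(=O)O[C@H](/C(C)=C/[C@@H]3CC[C@@H](Oc4ccc(O)cc4)[C@H](OC)C3)[C@H](C)[C@@H](O)CC1=O)[C@H](C)C[C@@H]2OC` carries 4-hydroxyphenyl; in this assay compound 2 gives 0.8 nM, the step being a 6.8-fold lower number from compound 1 to compound 2 (0.83 log units; beyond the scatter). Compound 3 `CC[C@@H]1/C=C(\C)C[C@H](C)C[C@H](OC)[C@H]2O[C@@](O)(C(=O)C(=O)N3CCCC[C@H]3C(=O)O[C@H](/C(C)=C/[C@@H]3CC[C@@H](Oc4cccc(O)c4)[C@H](OC)C3)[C@H](C)[C@@H](O)CC1=O)[C@H](C)C[C@@H]2OC` carries 3-hydroxyphenyl; in this assay compound 3 gives 1.7 nM, the second highest of the three numbers, with a 3.2-fold lower number from compound 1 to compound 3 (0.50 log units; beyond the scatter) and a 2.1-fold higher number from compound 2 to compound 3 (0.33 log units; beyond the scatter).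

Compound 4 `CC[C@@H]1/C=C(\C)C[C@H](C)C[C@H](OC)[C@H]2O[C@@](O)(C(=O)C(=O)N3CCCC[C@H]3C(=O)O[C@H](/C(C)=C/[C@@H]3CC[C@@H](Oc4ccc(OC)cc4)[C@H](OC)C3)[C@H](C)[C@@H](O)CC1=O)[C@H](C)C[C@@H]2OC` is the next analogue and remains unmeasured in this assay. The change from compound 3 is 4-methoxyphenyl in place of 3-hydroxyphenyl on an oxygen on a saturated carbon. Among the measured compounds shown here, two measured steps bear on it: the exchange of 4-hydroxyphenyl for 3-hydroxyphenyl, a 2.1-fold higher number from compound 2 to compound 3 (0.33 log units; beyond the scatter), and the replacement of methyl by hydroxy on the aromatic carbon, a 3.2-fold lower number from compound 1 to compound 3 (0.50 log units; beyond the scatter). For the measured compounds named here, no measured pair covers a methoxy, and no pair covers loss of the hydroxy donor while a 4-substituted aryl is kept. Compound 4 shares its 4-methoxyphenyl pattern most closely with the 4-hydroxyphenyl of compound 2, so a number between compound 2 and compound 1 is expected, and the step is estimated as a 1.2-fold higher number from compound 3 to compound 4 (0.07 log units; within the scatter), likely not beyond the scatter. Compound 4 is estimated at 2 nM, within 0.7 nM to 6 nM.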

Compound 4, half-maximal inhibitory concentration: 1.4 nM
For compound 4 the middle estimate is 1.4-fold (0.15 log units) above the measured one; the range from low to high includes it.
By their numbers in this assay, from the lowest: compounds 2, 4 and 3 (each within the scatter of the next, the first and the last beyond it); then compound 1.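

In this assay, among the compounds shown here, methyl in place of hydrogen on the oxygen on the aromatic ring stays within the scatter (a 1.8-fold higher number from compound 2 to compound 4 (0.24 log units; within the scatter)), which is the first direct reading of capping the hydroxy. The exchange of 3-hydroxyphenyl, with 1 hydrogen-bond donor, for 4-methoxyphenyl, with 0 hydrogen-bond donors, also stays within the scatter (a 1.2-fold lower number from compound 3 to compound 4 (0.08 log units; within the scatter)), so at this position the earlier gain over 3-methylphenyl does not depend on a hydroxy group, and the step to 4-methoxyphenyl remains beyond the scatter (a 3.9-fold lower number from compound 1 to compound 4 (0.59 log units; beyond the scatter)). No measurement here accounts for this tolerance of the methoxy group.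

The compounds shown leave open whether an unsubstituted phenyl on this oxygen would fall with compound 1 or with compounds 2, 3 and 4, which would show whether any oxygen substituent on the aromatic ring is needed. On these data alone, it also remains open whether an amine or a carboxylic acid on that ring, or a chain longer than methyl on its oxygen, would be tolerated in the same way.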